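A few compounds are considered here, and "the series" means these few. Any claim that something is new, unique, unknown or untested is made for them only; others in the source may bear on it.

Measured so far:
- compound 1 `O=C(Nc1cccc(-n2cc(-c3ccncc3)c(-c3cc(O)cc(Cl)c3)n2)c1)Nc1ccc(Cl)c(C(F)(F)F)c1`: 87%
- compound 2 `COc1cc(Cl)cc(-c2nn(-c3cccc(NC(=O)Nc4ccc(Cl)c(C(F)(F)F)c4)c3)cc2-c2ccncc2)c1`: 89%
- compound 3 `COc1cc(Cl)cc(-c2nn(-c3cccc(NC(=O)Nc4cc(C(F)(F)F)cc(C(F)(F)F)c4)c3)cc2-c2ccncc2)c1`: 50%

In a functional assay on Hs-578T cells (Homo sapiens) for inhibition, read by sulforhodamine B assay, with a stated time of 48 h, tested at 1 uM (on this read-out lower numbers stand for a stronger effect and higher numbers for a weaker effect at the one concentration tested), compound 2 gives 89%, the highest of the three numbers. Compound 1 lies nearest: the step of a number 2 percentage points higher from compound 1 to compound 2 (within the scatter) is within the scatter, so the two cannot be told apart. Going by the values given here, compound 3, with 50%, gives a number well below compound 2, a gap beyond the scatter; the two differ in the outer ring attached to the urea, but no single step between them is defined here.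

The unmeasured compound 4 `COc1cc(Cl)cc(-c2nn(-c3cccc(NC(=O)c4cccc(C(F)(F)F)c4)c3)cc2-c2ccncc2)c1` departs from compound 2 by 3-(trifluoromethyl)phenyl in place of (4-chloro-3-(trifluoromethyl)phenyl)amino on a carbonyl carbon. One nitrogen of the urea is thereby removed together with its chlorine-bearing ring, and a plain amide with one trifluoromethyl group remains. Among the compounds with values here, no measured step bears on this kind of change: the only step measured, from compound 1 to compound 2, touches the other end of the molecule and was within the scatter. Compound 3 shows that altering the outer ring can move the read-out considerably, but in which direction the present change acts cannot be read from the data.

Compound 4 is therefore expected to give about 78% in this assay, within 50% to 100%, meaning an estimated step of a number 11 percentage points lower from compound 2 to compound 4 (beyond the scatter).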

Compound 4, a percentage reported as activity, at one concentration (the size of the read-out at that concentration, not a potency): 52%
Compound 4: the middle estimate sits 26 percentage points above what was measured, and the stated range covers the measured number.
By their numbers in this assay, from the lowest: compounds 3 and 4 (each within the scatter of the next); then compounds 1 and 2 (each within the scatter of the next).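

In this assay, putting 3-(trifluoromethyl)phenyl in place of (4-chloro-3-(trifluoromethyl)phenyl)amino on the carbonyl carbon gives a number 37 percentage points lower from compound 2 to compound 4 (beyond the scatter), a stronger effect at the one concentration tested. Going by these compounds alone, this is the first measured single change at this end of the molecule to move the read-out beyond the scatter, whereas the only earlier step, a number 2 percentage points higher from compound 1 to compound 2 (within the scatter), lay at the other end and stayed within it. The change removes the urea nitrogen, with its hydrogen-bond donor, and the chlorine in one move, and no measurement available here explains the shift.

The compounds shown therefore leave open whether the loss of the nitrogen, the loss of the chlorine or both together account for the step; a compound with (3-(trifluoromethyl)phenyl)amino on the carbonyl carbon, or one with 4-chloro-3-(trifluoromethyl)phenyl directly on it, would pull the two apart. Going by these compounds, it is also open whether a methylene group in place of the nitrogen would behave like the urea or like the amide.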